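The source may hold more compounds than are shown below. What is called first, only, known or untested is meant among the compounds shown, and "the series" means these compounds.

In a functional assay on HeLa cells (Homo sapiens) for antiproliferative activity, read by CCK-8 assay, with a stated time of 72 h, tested at 2 uM (a lower number here means a weaker effect, a higher number a stronger effect of the compound at the concentration tested), compound 1 `Nc1ccccc1NC(=O)c1ccc(CSC(=S)N2CCc3ccccc32)cc1` gives 38%, the lowest of the two numbers shown, while compound 2 `COc1ccc(N2CCN(C(=S)SCc3ccc(C(=O)Nc4ccccc4N)cc3)CC2)cc1` gives 39.4% in this assay, a gap that stays within the usual scatter. Compound 3 `Nc1ccccc1NC(=O)c1ccc(CSC(=S)N2CCCC2)cc1`, not yet measured, differs from compound 1 in one place: pyrrolidin-1-yl in place of 2,3-dihydro-1H-indol-1-yl on a thiocarbonyl carbon. For the measured compounds named here, no pair of measured compounds shows what such a change does here, so the expected step is a guess: a small drop is expected, with a number 7 percentage points lower from compound 1 to compound 3 (within the scatter) lying within the scatter rather than beyond it. Compound 3 is estimated at 31%, with a range from 16% to 46%.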

Compound 3, a percentage reported as inhibition, at one concentration (the size of the read-out at that concentration, not a potency): 51.3%
For compound 3 the middle estimate is 20.3 percentage points below the measured one; measured number above the stated range.
By their numbers in this assay, from the lowest: compounds 1 and 2 (each within the scatter of the next); then compound 3.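

Placing pyrrolidin-1-yl in place of 2,3-dihydro-1H-indol-1-yl on a thiocarbonyl carbon gives, in this assay, a number 13.3 percentage points higher from compound 1 to compound 3 (beyond the scatter), so the group at this position can move the read-out beyond the scatter. The change removes the six-membered aromatic ring of carbon only and keeps a five-membered non-aromatic ring with one nitrogen. No available measurement explains this step.

Whether losing that aromatic ring alone accounts for the step stays open. Also open, as far as these compounds go, is how a piperidin-1-yl, morpholin-4-yl or diethylamino group at this position would read in this assay.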